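Series notes: a (4-chlorobenzyl)sulfanyl group in place of the oxygen-bound chain

This account rests on a few compounds, and the source may have more. Where it says the series, first, only, none or still open, it means among the compounds named here.

Two compounds of the series have numbers in an assay on microsomes from intestine for inhibition of acyl-CoA:cholesterol acyltransferase (Oryctolagus cuniculus); a lower number here means a stronger inhibitor, a higher number a weaker inhibitor. Compound 1 `CCCCCCCCOC(=O)NC(=O)Oc1c(C(C)C)cccc1C(C)C` gives 250 nM in this assay. Compound 2 `CCCCC(C)(C)OC(=O)NC(=O)Oc1c(C(C)C)cccc1C(C)C` gives 64 nM in this assay. For the measured compounds named here, the one measured step, a 3.9-fold lower number from compound 1 to compound 2 (0.59 log units; beyond the scatter), leaves compound 2 with the lowest of the two numbers; its only neighbour, compound 1, sits at the higher end of that step.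

Compound 3 `CC(C)c1cccc(C(C)C)c1OC(=O)NC(=O)SCc1ccc(Cl)cc1` has not yet been measured. Its change from compound 2 is a group of 9 heavy atoms (7 carbon, 1 sulfur, 1 chlorine; one six-membered aromatic ring of carbon only) in place of a group of 8 heavy atoms (7 carbon, 1 oxygen; no ring), on a carbonyl carbon, on a carbonyl carbon whose other neighbours are an amide-type nitrogen. Going by the values given here, only the step from compound 1 to compound 2 bears on this, and only loosely: that step swapped one chain for another on the oxygen, whereas compound 3 replaces the oxygen-bound group altogether with a group held through sulfur and carrying an aromatic ring. Among the compounds with values here, no measured pair shows such an exchange, so neither size nor direction can be read from the series. The step is therefore expected to be a 1.6-fold higher number from compound 2 to compound 3 (0.19 log units; within the scatter), which need not lie beyond the scatter, and the range is kept wide. Compound 3 is estimated at 100 nM in this assay, between 25 nM and 400 nM.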

Compound 3, half-maximal inhibitory concentration: 160 nM
For compound 3 the middle estimate is 1.6-fold (0.20 log units) below the measured one; the range from low to high includes it.
By their numbers in this assay, from the lowest: compound 2; then compounds 3 and 1 (each within the scatter of the next).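

In this assay, the carbonyl carbon whose other neighbours are an amide-type nitrogen also accepts a group held through sulfur and carrying an aromatic ring: (4-chlorobenzyl)sulfanyl in place of octyloxy gives a 1.6-fold lower number from compound 1 to compound 3 (0.19 log units; within the scatter) and leaves compound 1 and compound 3 indistinguishable. Against the branched chain of compound 2, the same group gives a 2.5-fold higher number from compound 2 to compound 3 (0.40 log units; beyond the scatter) and so does not match it, which leaves compound 2 with the lowest number of the three, its steps to both others lying beyond the scatter. No data at hand bear on the origin of these differences.

Sulfur, the benzyl group and the chlorine enter together, so the share of each in these steps stays unresolved; a benzyloxy group, an unsubstituted benzylsulfanyl group and an octylsulfanyl group at the same place would separate them. Going by these compounds, whether a 1,1-dimethylpentylsulfanyl group would keep the number of compound 2 also remains open, as does the effect of a fluorine or a methyl group in place of the chlorine.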